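Chloro for Hydrogen, Tried on a Second Core

The compounds below may be only part of what the source reports. "The series", "measured", "known", "first", "only" and "open" are said of these compounds alone.

Measured so far, in a functional assay on MDA-MB-231 cells (Homo sapiens) for cytotoxicity, read by sulforhodamine B assay, with a stated time of 48 h; on this read-out higher numbers stand for weaker inhibition of growth and lower numbers for stronger inhibition of growth:
compound 1 `Cc1ccc2nc(/N=C3\C(=O)N(CN4CCCCC4)c4ccccc43)sc2c1` gives 34500 nM;
compound 2 `CN(C)CN1C(=O)C(=O)c2ccccc21` gives 65600 nM;
compound 3 `Cc1ccc2nc(/N=C3\C(=O)N(CN4CCCCC4)c4cccc(Cl)c43)sc2c1` gives 55800 nM.

Compound 1 and compound 3 differ in one place only: chloro in place of hydrogen on an aromatic carbon. That change gave a 1.6-fold higher number from compound 1 to compound 3 (0.21 log units; within the scatter), so the two compounds cannot be told apart on this read-out.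

Compound 2 has a different core from compound 1, and the difference between the two cores is not broken down here. Its value sits close to those of compound 1 and compound 3, all three within the usual scatter of one another, so no order among them can be claimed.

Compound 4 `CN(C)CN1C(=O)C(=O)c2c(Cl)cccc21` is the not yet measured partner of compound 2. It carries the same change that turns compound 1 into compound 3: chloro in place of hydrogen on an aromatic carbon. The place of the change is described in the same words for both pairs, so this is the same change made on a second core.

For the measured compounds named here, for compound 4 in this assay a step of a 1.3-fold higher number from compound 2 to compound 4 (0.11 log units; within the scatter) is expected, resting on the only precedent, the step from compound 1 to compound 3 of a 1.6-fold higher number from compound 1 to compound 3 (0.21 log units; within the scatter), which stayed within scatter. On that basis compound 4 is estimated at 85000 nM, with a range from 35000 nM to 200000 nM expected.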

Compound 4, concentration for 50% growth inhibition: 138000 nM
Beside the measured number, compound 4's estimate is 1.6-fold (0.21 log units) below it; measured number inside the range.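

In this assay, chloro in place of hydrogen on an aromatic carbon gave a 2.1-fold higher number from compound 2 to compound 4 (0.32 log units; beyond the scatter), a modest loss of growth inhibition on the core of compound 2. Set beside the earlier step on the core of compound 1, this step cannot be told apart from it: the same change on two cores in this assay, a 1.6-fold higher number (0.21 log units; within the scatter) from compound 1 to compound 3 and a 2.1-fold higher number (0.32 log units; beyond the scatter) from compound 2 to compound 4, 1.3-fold (0.11 log units) apart, within the scatter of two such steps. For the compounds shown here, that fits a change that carries over between these two cores at a similar size, but it does not prove a general rule, since only two pairs stand behind it, only the step on the core of compound 2 lies beyond the scatter, and the numbers say nothing about what the chloro does.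

Left open is whether another group in the same place, such as fluoro, methoxy or a carboxylic acid, would give steps of similar size on both cores. Also open, as far as these compounds go, is whether chloro on another aromatic carbon of that ring would behave the same way, and whether the agreement between the two steps would hold on a third core.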